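Shortening the aldehyde chain of an endothelin receptor ligand

The compounds below may be only part of what the source reports. "The series", "measured", "known", "first", "only" and "open" are said of these compounds alone.

Compound 1 `Cc1onc(NS(=O)(=O)c2ccc(N)cc2)c1I`: 11000 nM
Compound 2 `COc1cccc(Sc2c(NS(=O)(=O)c3ccc(C(C)(C)C)cc3)noc2CCCCC=O)c1`: 1400 nM
Compound 3 `Cc1nsc(NS(=O)(=O)c2ccc(C(C)(C)C)cc2)c1C`: > 500000 nM (a limit of the assay)

Of the compounds shown here, three have been measured in an assay on A7R5 cells for displacement of a labelled ligand from Endothelin-1 receptor (Rattus norvegicus); on this read-out lower numbers stand for stronger inhibition and higher numbers for weaker inhibition. Compound 2 `COc1cccc(Sc2c(NS(=O)(=O)c3ccc(C(C)(C)C)cc3)noc2CCCCC=O)c1` gives 1400 nM in this assay, the lowest of the two numbers; compound 1 gives a higher number, and the gap between them lies beyond the scatter. Compound 3 gives only a limit in this assay, (the limit of > 500000 nM in this assay, at which 1 of the 3 values shown sits), and no number.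

Compound 4 `COc1cccc(Sc2c(NS(=O)(=O)c3ccc(C(C)(C)C)cc3)noc2CCC=O)c1` has not yet been measured. It differs from compound 2 by formyl in place of 2-formylethyl on a saturated chain carbon, two bonds along the chain from an aromatic carbon; the same difference, cut one bond further out, reads 4-formylbutyl to 2-formylethyl. Among the compounds with values here, no step between measured compounds shows what this shortening does, so the direction can only be guessed. A moderate weakening is expected, the step from compound 2 to compound 4 in this assay being estimated at a 2.1-fold higher number from compound 2 to compound 4 (0.33 log units; beyond the scatter). Compound 4 is therefore expected to give about 3000 nM, within a range of 800 nM to 12000 nM.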

Compound 4, half-maximal inhibitory concentration: 380 nM
For compound 4 the middle estimate is 7.9-fold (0.90 log units) above the measured one; the measured number lies below the stated range.
By their numbers in this assay, from the lowest: compound 4; then compound 2; then compound 1. At a limit, above all of these: compound 3.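

In this assay, within the data shown here, the change from 4-formylbutyl to 2-formylethyl gives a 3.7-fold lower number from compound 2 to compound 4 (0.57 log units; beyond the scatter) and so provides the only direct reading at this position, which runs towards stronger inhibition. Chain length at this place on the shared core therefore moves the result, even though the formyl end stays and the hydrogen-bond donor and acceptor counts of the exchanged groups are the same. Nothing shown here accounts for this change.

Among these compounds, with only two chain lengths to compare, the compounds leave open whether a 3-formylpropyl chain would fall between them and whether a still shorter formylmethyl chain would extend the gain or reverse it. They also leave open whether the aldehyde itself matters, which a carboxylic acid or a primary alcohol at the chain end would help to show.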